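The source may report more compounds than this note shows. Statements on the series, on what has been measured and on what is new or still open speak of the compounds shown alone.

Compound 1 `N#Cc1ccc(Nc2nc(Oc3ccnc4ccccc34)nc(N3CCC(Cc4ccccc4)CC3)n2)cc1C(F)(F)F` and compound 2 `N#Cc1ccc(Nc2nc(Oc3ccnc4ccccc34)nc(N3CCN(C(c4ccccc4)c4ccccc4)CC3)n2)cc1C(F)(F)F` share one core and differ only in the saturated ring on it. In a functional assay on DU-145 cells (Homo sapiens) for cytotoxicity, read by sulforhodamine B assay, with a stated time of 48 h (on this read-out lower numbers stand for stronger inhibition of growth and higher numbers for weaker inhibition of growth), compound 1 gives > 100000 nM, which is a limit of the assay and not a number. In this assay compound 2 gives > 100000 nM, again a limit. Both values sit at the limit of > 100000 nM in this assay, at which 2 of the 2 values shown sit. Compound 3 `N#Cc1ccc(Nc2nc(Oc3ccnc4ccccc34)nc(N3CCCCC3)n2)cc1C(F)(F)F` carries hydrogen in place of benzyl on a saturated ring carbon. Going by the values given here, no measured step in this assay bears on this change; the expected step of a number no higher from compound 1 to compound 3 (the limit leaves the size open) is none beyond the scatter. Compound 3 is estimated at 100000 nM, with a range from 30000 nM to 300000 nM, and a limit remains the likely outcome.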

Compound 3, concentration for 50% growth inhibition: 94900 nM
The estimate for compound 3 lay 1.1-fold (0.02 log units) above the measured number, and the stated range covers the measured number.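

In this assay, hydrogen in place of benzyl on the saturated ring carbon gives an at least 1.0-fold lower number from compound 1 to compound 3 (0.02 log units; that floor lies within the scatter). Compound 3 thus gives a true number where compound 1 gives only a limit, but the step shows no change beyond the scatter and leaves its upper size open. Activity at this position therefore remains weak with or without benzyl, and the values still crowd at the ceiling of the assay: the limit of > 100000 nM in this assay, at which 2 of the 3 values shown sit.

As far as these compounds go, the effect of an amine, a carboxylic acid or a longer chain on this saturated ring carbon stays open. So does whether any change at this position can bring growth inhibition clearly into the measurable range.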